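Swapping a Bulky Amine for Bromine on a Ketone Chain

The source may hold more compounds than are shown below. What is called first, only, known or untested is meant among the compounds shown, and "the series" means these compounds.

Compound 1 `CCCCCCc1ccc(C(=O)CCN(C(C)C)C(C)C)cc1` was tested in an in vitro assay on BL21-DE3 cells for displacement of a labelled ligand from thyroid hormone receptor beta (Homo sapiens), read by fluorescence polarization (a higher number here means a weaker inhibitor, a lower number a stronger inhibitor), where compound 1 gives 2000 nM, the lowest of the three numbers measured. Compound 2 `C=CC(=O)c1ccc(CCCCCCC)cc1` gives 10500 nM in this assay, and compound 3 `C=CC(=O)c1ccc(NC(=O)CCC)cc1` gives 85900 nM; both differ from compound 1 in more than one place, so only their values can be compared. Compound 4 `CCCCCCc1ccc(C(=O)CCBr)cc1` has not yet been measured. It differs from compound 1 in a single place: bromo in place of diisopropylamino on a saturated chain carbon, two bonds along the chain from a carbonyl carbon. Going by the values given here, no single-change step between measured compounds is available, so the expectation rests on the values shown. A shift toward the weaker side, beyond the scatter, is expected, a 2.5-fold higher number from compound 1 to compound 4 (0.40 log units; beyond the scatter). Compound 4 is accordingly estimated at 5000 nM, with a range from 1500 nM to 20000 nM.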

Compound 4, half-maximal inhibitory concentration: 3000 nM
Beside the measured number, compound 4's estimate is 1.7-fold (0.22 log units) above it; the range from low to high includes it.
By their numbers in this assay, from the lowest: compounds 1 and 4 (each within the scatter of the next); then compound 2; then compound 3.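

Exchanging diisopropylamino for bromo gives a 1.5-fold higher number from compound 1 to compound 4 (0.18 log units; within the scatter) in this assay, so the two compounds cannot be told apart in this read-out. At this saturated chain carbon, a group of 7 heavy atoms containing a nitrogen and a single bromine atom therefore give comparable values. Nothing available explains why these two groups read alike.

From the compounds shown here alone, whether chloro, hydroxyl or a smaller amine such as dimethylamino would also fit this place remains open. So does whether a longer chain between the carbonyl and the bromo would matter.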